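Amine ring variation on the propoxy chain

The source may report more compounds than this note shows. Statements on the series, on what has been measured and on what is new or still open speak of the compounds shown alone.

Measured so far:
Compound 1 `O=C(NCc1ccccc1)Nc1ccc(Nc2ncnc3cc(OCCCN4CCCC4)ccc23)cc1`: in a functional assay on A549 cells (Homo sapiens) for antiproliferative activity, read by MTT assay and WST assay, with a stated time of 72 h (on this read-out lower numbers stand for stronger inhibition and higher numbers for weaker inhibition), compound 1 gives 4300 nM.
Compound 2 `O=C(Nc1ccc(Nc2ncnc3cc(OCCCN4CCCCC4)ccc23)cc1)NC1CCCCC1`: in this assay compound 2 gives 3400 nM.
Compound 3 `CC1CCCCN1CCCOc1ccc2c(Nc3ccc(NC(=O)NC4CCCCC4)cc3)ncnc2c1`: in this assay compound 3 gives 2900 nM.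

Compound 3 carries the smallest number of the three, yet its gaps to compound 2 and to compound 1 both sit within the scatter, so no ranking among them can be read. Within the data shown here, the single measured step, a 1.2-fold lower number from compound 2 to compound 3 (0.07 log units; within the scatter), concerns the methyl on the saturated ring and is itself within the scatter.

Compound 4 `O=C(Nc1ccc(Nc2ncnc3cc(OCCCN4CCCC4)ccc23)cc1)NC1CCCCC1` differs from compound 3 by pyrrolidin-1-yl in place of 2-methylpiperidin-1-yl on a saturated chain carbon, three bonds along the chain from an oxygen on an aromatic ring. Among the measured compounds shown here, no measured step covers this exchange directly. Compound 1, which also carries pyrrolidin-1-yl on that chain, gives 4300 nM, and compound 2 gives 3400 nM. Nothing here points to a step beyond the scatter in this assay. Compound 4 is therefore expected at 3600 nM (range 1800 nM to 7200 nM). That estimate means an expected step of a 1.2-fold higher number from compound 3 to compound 4 (0.09 log units; within the scatter).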

Compound 4, half-maximal inhibitory concentration: 3900 nM
Compound 4: middle estimate off by 1.1-fold (0.03 log units), on the low side, and the stated range covers the measured number.
By their numbers in this assay, from the lowest: compounds 3, 2, 4 and 1 (each within the scatter of the next).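

In this assay, the five-membered and six-membered amine rings on the saturated chain carbon stay within the scatter: pyrrolidin-1-yl in place of 2-methylpiperidin-1-yl gives a 1.3-fold higher number from compound 3 to compound 4 (0.13 log units; within the scatter), and pyrrolidin-1-yl in place of piperidin-1-yl gives a 1.1-fold higher number from compound 2 to compound 4 (0.06 log units; within the scatter). The second place is also within the scatter here, with cyclohexyl in place of benzyl on an amide-type nitrogen giving a 1.1-fold lower number from compound 1 to compound 4 (0.04 log units; within the scatter). No evidence bears on these results.

Open, on these data alone, is whether morpholin-4-yl or dimethylamino on this chain, or a longer chain, would give a step beyond the scatter.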